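The source may hold more compounds than are shown below. What is called first, only, known or untested is meant among the compounds shown, and "the series" means these compounds.

Of the compounds shown here, three have been measured in an assay on cell membranes from brain for binding affinity to Adrenergic receptor alpha-1 (Rattus norvegicus), read by radioligand binding; a lower number here means a stronger inhibitor, a higher number a weaker inhibitor. Compound 1 `COc1ccccc1N1CCN(CCCn2nc(-n3cnc4ccccc43)ccc2=O)CC1` gives 6.5 nM. Compound 3 `COc1ccccc1N1CCN(CCCn2nc(-n3ccc4ccccc43)ccc2=O)CC1` gives 3.2 nM; it arises from compound 1 by 1H-indol-1-yl in place of 1H-benzimidazol-1-yl on an aromatic carbon, and that change gave a 2.0-fold lower number from compound 1 to compound 3 (0.31 log units; beyond the scatter). Compound 2 `COc1ccccc1N1CCN(CCCCCn2nc(-n3cnc4ccccc43)ccc2=O)CC1` gives 3.1 nM; how its core differs from the core of compound 1 is not broken down here. Compound 4 `COc1ccccc1N1CCN(CCCCCn2nc(-n3ccc4ccccc43)ccc2=O)CC1` has not yet been measured. It arises from compound 2 by 1H-indol-1-yl in place of 1H-benzimidazol-1-yl on an aromatic carbon, the same kind of change that turned compound 1 into compound 3, and the surroundings of the place are described in the same words in both cases. Because the earlier step was a 2.0-fold lower number from compound 1 to compound 3 (0.31 log units; beyond the scatter), a step of similar size is expected, a 1.9-fold lower number from compound 2 to compound 4 (0.29 log units; within the scatter). Compound 4 is therefore estimated to give about 1.6 nM, with a likely range from 0.7 nM to 4 nM.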

Compound 4, inhibition constant: 6.8 nM
For compound 4 the middle estimate is 4.3-fold (0.63 log units) below the measured one, and the stated range ends below it.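

In this assay, putting 1H-indol-1-yl in place of 1H-benzimidazol-1-yl gave a 2.2-fold higher number from compound 2 to compound 4 (0.34 log units; beyond the scatter), so the earlier step did not carry over, and the two steps run in opposite directions: the same change on two cores in this assay, a 2.0-fold lower number (0.31 log units; beyond the scatter) from compound 1 to compound 3 and a 2.2-fold higher number (0.34 log units; beyond the scatter) from compound 2 to compound 4, 4.5-fold (0.65 log units) apart, beyond the scatter of two such steps

For this change, then, the step seen on one core cannot be assumed to hold on the other. These two pairs do not show why the direction reverses, nor which way the step would run on a further core.

From the compounds shown here alone, it remains open how the same change would behave on a core with a longer chain. Also open, going by these compounds, is whether an amine on that aromatic carbon would follow either step.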